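The source may hold more compounds than are shown below. What is called first, only, known or untested is meant among the compounds shown, and "the series" means these compounds.

Measured compounds:

Compound 1, `OCC(O)COc1ccccc1Cl`: 1.29
Compound 2, `Cc1cc(Cl)c(OCCCO)c(Cl)c1`: 3.36
Compound 3, `OCCCOc1ccc(Cl)cc1`: 2.36

The read-out throughout is a physicochemical assay for lipophilicity, measured as octanol-water partition; on this read-out lower numbers stand for lower lipophilicity and higher numbers for higher lipophilicity. Among the three measured compounds, compound 1 stands lowest. Its nearest neighbour is compound 3, whose value lies beyond the scatter above it, and the furthest is compound 2, whose value lies further still above it, also beyond the scatter. Among the compounds with values here, no pair among the measured compounds differs in only one place, so no single structural step has yet been measured here.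

The step under consideration leads from compound 1 to the unmeasured compound 4, `CC(O)COc1ccccc1Cl`. The change is hydrogen in place of hydroxy on a saturated chain carbon, two bonds along the chain from an oxygen on a saturated carbon. Seen one bond further out, a hydroxymethyl becomes a methyl, or a 1,2-dihydroxyethyl becomes a 1-hydroxyethyl.

Nothing measured here shows this exact step, so the expectation rests on the structural change alone: losing a hydroxy that counts as both a hydrogen-bond donor and a hydrogen-bond acceptor is expected to raise this assay, by a step well beyond the scatter. The step from compound 1 to compound 4 is estimated at a number 0.91 log units higher from compound 1 to compound 4 (beyond the scatter). Compound 4 is therefore expected to come in at about 2.2, somewhere between 1.8 and 2.6.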

Compound 4, partition coefficient: 2.05
Estimate against measurement, compound 4: 0.15 log units above; low and high end bracket the measured number.
By their numbers in this assay, from the lowest: compound 1; then compound 4; then compound 3; then compound 2.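

In this assay, within the data shown here, putting hydrogen in place of hydroxy on a saturated chain carbon, two bonds along the chain from an oxygen on a saturated carbon, gives a number 0.76 log units higher from compound 1 to compound 4 (beyond the scatter) as the first step here that can be read in a single place. The earlier compounds shown here differed from one another in more than one place, so their values could not show what this one hydroxy is worth on its own; this pair isolates that change, with the rest of the core of compound 1 left as it stands. Nothing in the material shown explains the size of the step, which therefore stands as an observation and not as an explained effect.

The compounds shown leave open how an amine, a carboxylic acid or a methoxy would read at this same place, and how a longer chain would read in place of the methyl. Going by these compounds, with this single pair in view, it also stays open whether exchanging hydroxy for hydrogen would give a step of similar size elsewhere on the chain or on a different core.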